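Halogen swap on the dicyanophenyl-type arm of the series

This account rests on a few compounds, and the source may have more. Where it says the series, first, only, none or still open, it means among the compounds named here.

Measured so far:
compound 1 `Cc1nc(C#Cc2cc(C#N)cc([N+](=O)[O-])c2)cs1` — 0.36 nM
compound 2 `Cc1nc(C#Cc2cc(Br)cc([N+](=O)[O-])c2)cs1` — 0.93 nM
compound 3 `Cc1nc(C#Cc2cc(Cl)cc(C#N)c2)cs1` — 0.127 nM

All three numbers come from an assay on HEK293 cells for displacement of a labelled ligand from metabotropic glutamate receptor 5 (Rattus norvegicus), read by scintillation counting; a lower number here means a stronger inhibitor, a higher number a weaker inhibitor. Compound 3 stands lowest of the three in this assay: the step from compound 1 to compound 3 was a 2.8-fold lower number from compound 1 to compound 3 (0.45 log units; beyond the scatter), and compound 2 lies furthest from it. Compound 4 `Cc1nc(C#Cc2cc(I)cc(C#N)c2)cs1` is not yet measured; it differs from compound 3 by iodo in place of chloro on an aromatic carbon. For the measured compounds named here, no measured step exchanges one halogen for another. The steps that exist, bromo in place of cyano a 2.6-fold higher number from compound 1 to compound 2 (0.41 log units; beyond the scatter) and chloro in place of nitro a 2.8-fold lower number from compound 1 to compound 3 (0.45 log units; beyond the scatter), both change the kind of group and are only modest, so no step beyond the scatter is expected here. The expected move from compound 3 to compound 4 is estimated as a 1.2-fold higher number from compound 3 to compound 4 (0.07 log units; within the scatter). For compound 4 the expected value in this assay is 0.15 nM, estimated range 0.06 nM to 0.4 nM.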

Compound 4, inhibition constant: 2.14 nM
For compound 4 the middle estimate is 14-fold (1.15 log units) below the measured one, and the stated range ends below it.
By their numbers in this assay, from the lowest: compound 3; then compound 1; then compound 2; then compound 4.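

In this assay, for the compounds shown here, the halogen on this aromatic carbon, meta to a cyano group, is not interchangeable, with a 17-fold higher number from compound 3 to compound 4 (1.23 log units; beyond the scatter) as the only step that exchanges one halogen for another. With a 5.9-fold higher number from compound 1 to compound 4 (0.77 log units; beyond the scatter) iodo also stands behind nitro on the same carbon. Nothing available explains this loss.

Open, going by these compounds, is where bromo would fall with the cyano group kept, and whether the rise runs steadily from chloro to iodo. Also open, on these data alone, is how fluoro, methoxy or an amine at this place would compare with chloro.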